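This account rests on a few compounds, and the source may have more. Where it says the series, first, only, none or still open, it means among the compounds named here.

Numbers in a functional assay on PC-12 cells (Rattus norvegicus) for cytotoxicity, read by MTT assay, with stated times of 3 h and 2 h, tested at 20 uM (a higher number here means a stronger effect of the compound at the concentration tested, a lower number a weaker effect), for the three measured members of the series:

compound 1, `CCOC(=O)c1cc2ccc(OCCCn3cc(CNC(=O)CCCCC4CCSS4)nn3)cc2oc1=O`: 42.1%
compound 2, `O=C(CCCCC1CCSS1)NCc1cn(CCCOc2ccc3cc(C(=O)O)c(=O)oc3c2)nn1`: 66.8%
compound 3, `COc1ccc(-c2cc3ccc(OCCCn4cc(CNC(=O)CCCCC5CCSS5)nn4)cc3oc2=O)cc1`: 62%

Compound 3 holds the second highest of the three numbers. Its nearest neighbour is compound 2, and the difference a number 4.8 percentage points lower from compound 2 to compound 3 (within the scatter) stays within the scatter, so the two cannot be ordered. Its furthest neighbour is compound 1, and the step of a number 19.9 percentage points higher from compound 1 to compound 3 (beyond the scatter) is beyond the scatter. The remaining step, a number 24.7 percentage points higher from compound 1 to compound 2 (beyond the scatter), also lies beyond the scatter.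

Compound 4, `O=C(CCCCC1CCSS1)NCc1cn(CCCOc2ccc3cc(-c4ccc(Br)cc4)c(=O)oc3c2)nn1`, differs from compound 3 by bromo in place of methoxy on an aromatic carbon. Among the compounds with values here, no measured step in this set touches that position: the steps of a number 19.9 percentage points higher from compound 1 to compound 3 (beyond the scatter) and a number 4.8 percentage points lower from compound 2 to compound 3 (within the scatter) concern the whole 4-methoxyphenyl entering in place of ethoxycarbonyl or carboxy, and the step of a number 24.7 percentage points higher from compound 1 to compound 2 (beyond the scatter) concerns the ester against the acid. Within the data shown here, the exchange of one small substituent at the far end of the pendant phenyl has no precedent here, so a step beyond the scatter is not expected in either direction; the expected change is no change at the digits printed from compound 3 to compound 4 (within the scatter). For compound 4 the estimate in this assay is 62%, with a range from 46% to 78%.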

Compound 4, a percentage reported as activity, at one concentration (the size of the read-out at that concentration, not a potency): 69.1%
Compound 4: the middle estimate sits 7.1 percentage points below what was measured; low and high end bracket the measured number.
By their numbers in this assay, from the lowest: compound 1; then compounds 3, 2 and 4 (each within the scatter of the next).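

In this assay, within the data shown here, this is the only reading at the far end of the pendant phenyl, on the aromatic carbon para to a large group, and bromo in place of methoxy gives a number 7.1 percentage points higher from compound 3 to compound 4 (within the scatter) so the exchange cannot be told from no effect at this position. The 4-bromophenyl group also gives a number 2.3 percentage points higher from compound 2 to compound 4 (within the scatter) against the carboxy group and a number 27 percentage points higher from compound 1 to compound 4 (beyond the scatter) against the ethoxycarbonyl group, so compounds 2, 3 and 4 cannot be ordered among themselves, while each stands beyond the scatter from compound 1, as the 4-methoxyphenyl group already did with a number 19.9 percentage points higher from compound 1 to compound 3 (beyond the scatter) in the same assay. Nothing at hand bears on why these numbers fall as they do.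

Open, on these data alone, is whether a nitrile, an amine or a carboxylic acid at the same place on the phenyl would also stay within the scatter of compound 3 and compound 4, or whether only groups like methoxy and bromo do. Also open, as far as these compounds go, is how the unsubstituted phenyl would read against both of them in this assay at the single concentration used there.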